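The source may hold more compounds than are shown below. What is called first, only, known or untested is meant among the compounds shown, and "the series" means these compounds.

Measured so far:
compound 1 `COc1ccc(-n2c(Nc3nc(-c4ccc([N+](=O)[O-])cc4)cs3)n[nH]c2=S)cc1` — 100 mg/kg
compound 2 `COc1ccc(-n2c(Nc3nc(-c4ccccc4)cs3)n[nH]c2=S)cc1` — 100 mg/kg

In a functional assay on the whole organism (strain Swiss albino) for inhibition, with Mus musculus as the target, with a stated time of 0.5 h (on this read-out lower numbers stand for an effect already at smaller amounts and higher numbers for an effect only at larger amounts of compound), compound 1 gives 100 mg/kg, and compound 2 gives 100 mg/kg. Compound 1 therefore stands level with compound 2 at the digits shown; the single measured step, no change at the digits printed from compound 1 to compound 2 (within the scatter), is hydrogen in place of nitro on an aromatic carbon and lies within the scatter.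

Compound 3 `Cc1ccccc1-n1c(Nc2nc(-c3ccc([N+](=O)[O-])cc3)cs2)n[nH]c1=S` differs from compound 1 by 2-methylphenyl in place of 4-methoxyphenyl on an aromatic nitrogen. Going by the values given here, no measured pair alters the group on the aromatic nitrogen; the step from compound 1 to compound 2 touches a different place and does not bear on this change. Among the compounds with values here, the only information on the series is that its one substitution left the minimum effective dose unchanged, so the expected step is none beyond the scatter: no change at the digits printed from compound 1 to compound 3 (within the scatter) is expected. Compound 3 is estimated at 100 mg/kg, with a range from 50 mg/kg to 200 mg/kg.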

Compound 3, minimum effective dose: 100 mg/kg
Estimate against measurement, compound 3: no gap at the digits printed; measured number inside the range.
By their numbers in this assay, from the lowest: compounds 1, 2 and 3 (each within the scatter of the next).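

In this assay the group on the aromatic nitrogen gives its first reading: with 2-methylphenyl in place of 4-methoxyphenyl there is no change at the digits printed from compound 1 to compound 3 (within the scatter). So the second varied position of the series also leaves the minimum effective dose flat, even though the entering group has no oxygen and no hydrogen-bond acceptor and carries its substituent at a different place on the phenyl ring. No supporting data bear on why this exchange leaves the read-out unmoved.

As far as these compounds go, both groups seen at this nitrogen are substituted phenyl rings, so it remains open whether a phenyl ring carrying a carboxylic acid or an amine would shift the dose. Also open, from the compounds shown here alone, is whether a plain butyl chain in place of the aromatic ring would hold the same level.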